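The compounds below may be only part of what the source reports. "The series", "measured", "known", "first", "only" and "open" are said of these compounds alone.

- Compound 1 `COCOc1cc(O)ccc1/C=C/C(=O)c1ccc(O)cc1O` gives "not determined" (no result reported)
- Compound 2 `COc1cc(OC)c(OC)cc1/C=C/C(=O)c1ccc(O)cc1O` gives 60000 nM
- Compound 3 `O=C(/C=C/c1ccc(C(F)(F)F)cc1)c1ccc(O)cc1O` gives "not determined" (no result reported)

These entries come from a functional assay on NCI-H460 cells (Homo sapiens) for inhibition, read by sulforhodamine B assay, with a stated time of 48 h; on this read-out higher numbers stand for weaker inhibition of growth and lower numbers for stronger inhibition of growth. Compound 3 has no single number to stand on, since its entry reads "not determined" (no result reported), and compound 1 is in the same position with "not determined" (no result reported). Within the data shown here, only compound 2 carries a number, and no two measured compounds differ in just one place, so the data contain no measured step.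

Compound 4 `O=C(/C=C/c1ccc(F)cc1)c1ccc(O)cc1O` has no result yet. Its structure differs from that of compound 3 by one small edit: fluoro in place of trifluoromethyl on an aromatic carbon. In words, this is fluoro in place of trifluoromethyl on an aromatic carbon, para to a large group, and the rest of the structure stays the same.

Among the measured compounds shown here, compound 3 offers no starting number, and no measured pair shows what this kind of swap does in this assay. No step beyond the usual scatter is therefore expected, in either direction. For the measured compounds named here, the expectation for compound 4 instead leans on compound 2 at 60000 nM, the one number available for the shared core. For compound 4 the estimated value is 40000 nM, with an expected range from 12000 nM to 100000 nM.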

Compound 4, concentration for 50% growth inhibition: 15300 nM
For compound 4 the middle estimate is 2.6-fold (0.42 log units) above the measured one, within the range that was stated.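

In this assay, among these compounds, compound 4 carries a single number but compound 3 does not, so no step between compound 3 and compound 4 can be read. As far as these compounds go, what replacing trifluoromethyl with fluoro does to growth inhibition on the shared core therefore stays open. Nothing shown here offers an explanation for the value of compound 4.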